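This account rests on a few compounds, and the source may have more. Where it says the series, first, only, none or still open, it means among the compounds named here.

Measured so far:
compound 1 `N#Cc1ccc2c(c1)C(N1CCCC1=O)=CC(CF)(CF)O2` — 102 nM
compound 2 `N#Cc1ccc2c(c1)C(N1CCCCC1=O)=CC(CF)(CF)O2` — 162 nM

Both were tested in a functional assay (aorta) with Rattus norvegicus as the target; on this read-out higher numbers stand for an effect only at larger amounts of compound and lower numbers for an effect already at smaller amounts. Within the data shown here, compound 2 has the highest of the two numbers, but the only measured step, a 1.6-fold higher number from compound 1 to compound 2 (0.20 log units; within the scatter), concerns the lactam ring and is within the scatter. Compound 3 `O=C1CCCCN1C1=CC(CF)(CF)Oc2ccc(C(F)(F)C(F)(F)F)cc21` differs from compound 2 by 1,1,2,2,2-pentafluoroethyl in place of cyano on an aromatic carbon. Among the measured compounds shown here, no measured step touches this position, so there is nothing to anchor a prediction; the direction is open. The expected step is a 1.5-fold higher number from compound 2 to compound 3 (0.19 log units; within the scatter), and compound 3 is estimated at 250 nM, with a range from 60 nM to 1000 nM.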

Compound 3, half-maximal effective concentration: 5.62 nM
For compound 3 the middle estimate is 44-fold (1.65 log units) above the measured one; measured number outside the range, below it.
By their numbers in this assay, from the lowest: compound 3; then compounds 1 and 2 (each within the scatter of the next).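

The aromatic carbon that carries the cyano group responds strongly in this assay: replacing cyano with 1,1,2,2,2-pentafluoroethyl gives a 29-fold lower number from compound 2 to compound 3 (1.46 log units; beyond the scatter), so the effect appears at much smaller amounts of compound. Among these compounds, the earlier lactam ring change gave only a step within the scatter, so this is the first sign that the compounds are sensitive to a change in one place. Nothing available explains the size of this step.

On these data alone, how trifluoromethyl, ethyl or an amine on this aromatic carbon would compare remains open. So does whether 2-oxopyrrolidin-1-yl would give a similar number alongside 1,1,2,2,2-pentafluoroethyl.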